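Swapping Dimethylamino for Azetidin-1-yl on a Shared Core

The source may report more compounds than this note shows. Statements on the series, on what has been measured and on what is new or still open speak of the compounds shown alone.

Compound 1 `CCCCCCCCCCCCCCCCc1c(C)c(N(C)C)nc(C)c1O` and compound 2 `CCCCCCCCCCc1c(C)c(N(C)C)nc(C)c1O` share one core and differ only in the length of the saturated chain. In a functional assay on cells (Lymphocyte, Homo sapiens), read by trypan blue exclusion, with a stated time of 16 h, tested at 0.5 uM (on this read-out lower numbers stand for a weaker effect and higher numbers for a stronger effect at the one concentration tested), compound 1 gives 75%, and compound 2 gives 84%. Of the two numbers, compound 1 has the smaller one, but the step of a number 9 percentage points higher from compound 1 to compound 2 (within the scatter) falls within the scatter, so these two compounds cannot be told apart on this read-out.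

Compound 3 `CCCCCCCCCCCCCCCCc1c(C)c(N2CCC2)nc(C)c1O` keeps the long chain of compound 1 and changes the amine on the ring: azetidin-1-yl in place of dimethylamino on an aromatic carbon. Among the compounds with values here, no measured step touches this part of the molecule; the only step known concerns the chain, and it was small. There is therefore no basis for expecting a shift beyond the scatter in this assay. Compound 3 is estimated at 75%, with a likely range from 55% to 92%, meaning an expected step of no change at the digits printed from compound 1 to compound 3 (within the scatter).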

Compound 3, a percentage reported as activity, at one concentration (the size of the read-out at that concentration, not a potency): 79%
The estimate for compound 3 lay 4 percentage points below the measured number, and the stated range covers the measured number.
By their numbers in this assay, from the lowest: compounds 1, 3 and 2 (each within the scatter of the next).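

The earlier compounds shown here varied only the saturated chain, so this pair gives the first view of the amine on the aromatic carbon. With the long chain held fixed, putting azetidin-1-yl in place of dimethylamino gives a number 4 percentage points higher from compound 1 to compound 3 (within the scatter) in this assay, so the two amines cannot be told apart on this read-out, and this position accepts a four-membered ring without a change that can be resolved here. No available measurement offers an explanation for this result.

These compounds leave open whether a larger ring amine such as piperidin-1-yl, or a plain amino group, would also stay within the scatter at this position. As far as these compounds go, it also remains open whether azetidin-1-yl would behave the same way on the shorter chain of compound 2.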